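Notes on the pyrimidine substituent in the series

A few compounds are considered here, and "the series" means these few. Any claim that something is new, unique, unknown or untested is made for them only; others in the source may bear on it.

Compound 1 `Cc1ncc(-c2nc(C(F)(F)F)sc2N2CCN(C(=O)Cn3cnc4cccnc43)[C@H](C)C2)cn1` and compound 2 `Cc1ncc(-c2nc(C(F)(F)F)sc2N2CCN(C(=O)Cn3nc(C)nc3C)[C@H](C)C2)cn1` share one core and differ only in the group on the saturated chain carbon bound to the carbonyl carbon. Among the compounds with values here, in a functional assay on CHO-K1 cells for antagonist activity at C-X-C chemokine receptor type 3 (Homo sapiens), read by FLIPR, with a stated time of 10 min (on this read-out lower numbers stand for stronger inhibition and higher numbers for weaker inhibition), compound 1 gives 3.6 nM and compound 2 gives 19 nM; the step of a 5.3-fold higher number from compound 1 to compound 2 (0.72 log units; beyond the scatter) leaves compound 2 with the highest of the two numbers measured so far. Compound 3 `Cc1nc(C)n(CC(=O)N2CCN(c3sc(C(F)(F)F)nc3-c3cnc(N4CCCC4)nc3)C[C@H]2C)n1` keeps the side chain of compound 2 and alters the distal ring: pyrrolidin-1-yl in place of methyl on an aromatic carbon, that is 2-methylpyrimidin-5-yl to 2-(pyrrolidin-1-yl)pyrimidin-5-yl. Within the data shown here, no measured step touches this position; the single step seen concerns the amide side chain alone, so neither direction nor size can be read from the data. The expectation is therefore a number close to that of compound 2, with wide uncertainty. Compound 3 is estimated at 15 nM, with a range from 4 nM to 60 nM. The expected step is a 1.3-fold lower number from compound 2 to compound 3 (0.10 log units; within the scatter), likely within the scatter.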

Compound 3, half-maximal inhibitory concentration: 3.5 nM
For compound 3 the middle estimate is 4.3-fold (0.63 log units) above the measured one, outside the stated range (below it).
By their numbers in this assay, from the lowest: compounds 3 and 1 (each within the scatter of the next); then compound 2.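

The position on the aromatic carbon between two ring nitrogen atoms, para to a large group, is not silent: in this assay the change from 2-methylpyrimidin-5-yl to 2-(pyrrolidin-1-yl)pyrimidin-5-yl gives a 5.4-fold lower number from compound 2 to compound 3 (0.73 log units; beyond the scatter) with the side chain held fixed. Until now, only the amide side chain had been seen to move the number, and this step shows that the distal ring can move it as well, here with pyrrolidin-1-yl in place of methyl. Nothing available bears on what lies behind this step.

As far as these compounds go, it remains open whether a smaller amine such as dimethylamino, a six-membered ring such as morpholin-4-yl, or an ether such as methoxy would follow pyrrolidin-1-yl here. Also open, from the compounds shown here alone, is whether the same step would hold with the side chain of compound 1.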